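This account rests on a few compounds, and the source may have more. Where it says the series, first, only, none or still open, it means among the compounds named here.

Measured so far in a functional assay on the whole organism (strain albino Sprague-Dawley) with Rattus norvegicus as the target, in the maximal electroshock model; on this read-out lower numbers stand for an effect already at smaller amounts and higher numbers for an effect only at larger amounts of compound:
- compound 1 `CC(C)(C)[C@@H](N)C(=O)NCc1ccc(COc2cccc(F)c2)cc1`: 30 mg/kg
- compound 2 `CC(C)[C@@H](N)C(=O)NCc1ccc(COc2cccc(F)c2)cc1`: a limit, < 30 mg/kg
- compound 3 `CC(C)(C)[C@@H](N)C(=O)NCc1ccc(-c2ccccc2)cc1`: "not determined" (no result reported)

Compound 1 `CC(C)(C)[C@@H](N)C(=O)NCc1ccc(COc2cccc(F)c2)cc1` gives 30 mg/kg in this assay. For compound 2 `CC(C)[C@@H](N)C(=O)NCc1ccc(COc2cccc(F)c2)cc1` the result is a limit of the assay and not a number, < 30 mg/kg. The step of a number no higher from compound 1 to compound 2 (the limit leaves the size open) is therefore of open size; the change behind it is hydrogen in place of methyl on a saturated chain carbon bound to three saturated chain carbons. The limit itself is recorded as the limit of < 30 mg/kg in this assay, at which 1 of the 3 values shown sits.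

Compound 3 `CC(C)(C)[C@@H](N)C(=O)NCc1ccc(-c2ccccc2)cc1` carries the same side chain as compound 1 on a different core; how the two cores differ is not broken down here, and for compound 3 the entry in this assay reads "not determined" (no result reported).

Compound 4 `CC(C)[C@@H](N)C(=O)NCc1ccc(-c2ccccc2)cc1` stands to compound 3 as compound 2 stands to compound 1: the change is hydrogen in place of methyl on a saturated chain carbon bound to three saturated chain carbons, the same change at the same kind of place. With no number for compound 3, the size of the step from compound 3 to compound 4 in this assay cannot be anchored. The expectation rests on compound 1 with 30 mg/kg and on the direction of a number no higher from compound 1 to compound 2 (the limit leaves the size open), which is no worse. Compound 4 is therefore expected to fall near 30 mg/kg, within a broad span from 8 mg/kg to 100 mg/kg, with a real chance that the assay again returns only a limit.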

Compound 4, dose for half-maximal effect: 30 mg/kg
The estimate for compound 4 equals the measured number at the digits printed; low and high end bracket the measured number.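

In this assay compound 4 gives 30 mg/kg, while compound 3 carries no number, so no step can be read from compound 3 to compound 4. The compounds shown leave open how large the change from tert-butyl to isopropyl is on either core, and whether it is of similar size on both, with one result still only a limit: the limit of < 30 mg/kg in this assay, at which 1 of the 4 values shown sits.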